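The source may report more compounds than this note shows. Statements on the series, on what has been measured and on what is new or still open speak of the compounds shown alone.

Three compounds share one core and differ only in the chain attached to its aromatic nitrogen. In an assay on Prostate gland for inhibition of steroid 5-alpha-reductase (Rattus norvegicus) (on this read-out lower numbers stand for stronger inhibition and higher numbers for weaker inhibition), compound 1 `CCCn1ccc2cc(/C(C)=C/C(=O)Nc3ccccc3OCCCC(=O)O)ccc21` gives 190 nM. Compound 2 `CCCCCCCn1ccc2cc(/C(C)=C/C(=O)Nc3ccccc3OCCCC(=O)O)ccc21` gives 120 nM, and compound 3 `CCC(C)n1ccc2cc(/C(C)=C/C(=O)Nc3ccccc3OCCCC(=O)O)ccc21` gives 67 nM. Compound 3 thus has the lowest of the three numbers, but its gap to compound 2 lies within the scatter; only the change from compound 1 is clear, as a 2.8-fold lower number from compound 1 to compound 3 (0.45 log units; beyond the scatter) shows. Compound 4 `CCCCC(C)n1ccc2cc(/C(C)=C/C(=O)Nc3ccccc3OCCCC(=O)O)ccc21` brings (ethyl in place of hydrogen on a saturated chain carbon, three bonds along the chain from an aromatic nitrogen). Going by the values given here, the one earlier step at this place, a 1.6-fold lower number from compound 1 to compound 2 (0.20 log units; within the scatter), stayed within the scatter. The same is expected here, giving a 1.2-fold lower number from compound 3 to compound 4 (0.09 log units; within the scatter). For compound 4 the estimate is 55 nM, with a range from 25 nM to 120 nM.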

Compound 4, half-maximal inhibitory concentration: 6 nM
Compound 4: middle estimate off by 9.2-fold (0.96 log units), on the high side; measured number outside the range, below it.
By their numbers in this assay, from the lowest: compound 4; then compounds 3, 2 and 1 (each within the scatter of the next, the first and the last beyond it).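

The same place on the chain now behaves very differently: ethyl in place of hydrogen gives an 11-fold lower number from compound 3 to compound 4 (1.05 log units; beyond the scatter), whereas the butyl step gave only a 1.6-fold lower number from compound 1 to compound 2 (0.20 log units; within the scatter). The 1-methylpentyl group of compound 4 also stands clear of the straight chains, with a 20-fold lower number from compound 2 to compound 4 (1.30 log units; beyond the scatter) and a 32-fold lower number from compound 1 to compound 4 (1.50 log units; beyond the scatter). Nothing available explains this jump.

Still open, on these data alone, is whether a longer chain such as 1-methylheptyl would lower the number further or raise it again. Equally open, as far as these compounds go, is how a ring such as cyclohexyl would compare at this nitrogen.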